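The compounds below may be only part of what the source reports. "The series", "measured", "known", "first", "only" and "open" are said of these compounds alone.

Compound 1, `C[C@H](NC(=O)Nc1cccc(C(F)(F)F)c1)c1ccccc1`: 94%
Compound 2, `CCOC(=O)c1cccc(NC(=O)N[C@@H](C)c2ccccc2)c1`: 100%
Compound 3, `CC(=O)c1cccc(NC(=O)N[C@@H](C)c2ccccc2)c1`: 96%

All three compounds share one core and differ only in the group on one aromatic carbon. In an ADME assay on the whole organism with Oryza sativa as the target, tested at 0.1 uM (on this read-out higher numbers stand for a weaker effect at the one concentration tested and lower numbers for a stronger effect), compound 3 gives 96%, the second highest of the three numbers. Its nearest neighbour is compound 1, with a number 2 percentage points higher from compound 1 to compound 3 (within the scatter); the furthest is compound 2, with a number 4 percentage points lower from compound 2 to compound 3 (within the scatter). Both steps lie within the scatter, so none of the three stands apart from the others.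

Compound 4, `C[C@H](NC(=O)Nc1cccc(F)c1)c1ccccc1`, has not yet been measured. It arises from compound 3 by fluoro in place of acetyl on an aromatic carbon. Within the data shown here, every measured step so far was an exchange at this same aromatic carbon: trifluoromethyl to ethoxycarbonyl in a number 6 percentage points higher from compound 1 to compound 2 (within the scatter), trifluoromethyl to acetyl in a number 2 percentage points higher from compound 1 to compound 3 (within the scatter), and ethoxy to methyl on the carbonyl carbon in a number 4 percentage points lower from compound 2 to compound 3 (within the scatter). All of them stayed within the scatter. Among the measured compounds shown here, no measured step involves fluoro, so the expectation rests only on the observation that swapping this group has changed nothing so far. In this assay compound 4 is therefore expected to show a number 1 percentage points lower from compound 3 to compound 4 (within the scatter), no step beyond the scatter. The estimate for compound 4 is 95%, with a range from 84% to 100%.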

Compound 4, a percentage reported as activity, at one concentration (the size of the read-out at that concentration, not a potency): 97%
The estimate for compound 4 lay 2 percentage points below the measured number; low and high end bracket the measured number.
By their numbers in this assay, from the lowest: compounds 1, 3, 4 and 2 (each within the scatter of the next).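

Swapping acetyl for fluoro takes away a group of three heavy atoms, with its double bond and its hydrogen-bond acceptor, and puts a single heavy atom in its place, yet in this assay this gives a number 1 percentage points higher from compound 3 to compound 4 (within the scatter). Fluoro also stays close to the two other groups at this aromatic carbon, with a number 3 percentage points lower from compound 2 to compound 4 (within the scatter) and a number 3 percentage points higher from compound 1 to compound 4 (within the scatter), so four different groups at this one position now give numbers that all lie within the scatter of one another, and this shrinking of the group to one heavy atom is a kind of change the earlier compounds did not include. Nothing measured here offers a reason for this lack of response.

As far as these compounds go, whether any group at this aromatic carbon can move the number beyond the scatter remains open, for example an amine, a carboxylic acid or a longer chain such as butyl. Also open, from the compounds shown here alone, is how this assay responds to changes elsewhere on the shared core, and whether these four compounds would stay this close at a concentration other than the one tested.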